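Chloro in place of hydrogen at the benzyl end of compound 3

The source may hold more compounds than are shown below. What is called first, only, known or untested is meant among the compounds shown, and "the series" means these compounds.

Of the compounds shown here, three have been measured in a functional assay on the whole organism (artery, strain albino) with Rattus norvegicus as the target, with a stated time of 360 min, at a dose of 10 mg/kg by the oral route; a lower number here means less inhibition, a higher number more inhibition at the dose given (going by the name of the read-out). Compound 1, `COc1ccc(C2N=C(SCc3cccc(Cl)c3)NC(C)=C2C(=O)Nc2ccc(F)cc2)cc1OC`, gives 20.1%. Compound 2, `COc1ccc(C2N=C(SCc3ccc(F)cc3)NC(C)=C2C(=O)Nc2ccc(Br)cc2)cc1`, gives 33.5%. Compound 3, `CC1=C(C(=O)Nc2ccc([N+](=O)[O-])cc2)C(c2ccc(Br)cc2)N=C(SCc2ccccc2)N1`, gives 37.6%. The number for compound 3 is the highest of the three, yet the gap to compound 2 lies within the scatter, so the two cannot be told apart; only compound 1 falls beyond the scatter below compound 3. For the measured compounds named here, no pair of measured compounds differs in one place, so no single structural change has yet been followed on its own.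

Compound 4, `CC1=C(C(=O)Nc2ccc([N+](=O)[O-])cc2)C(c2ccc(Br)cc2)N=C(SCc2cccc(Cl)c2)N1`, is the next compound to be measured in this assay. It differs from compound 3 in one respect: chloro in place of hydrogen on an aromatic carbon. Compound 1 also carries a 3-chlorobenzyl group and gives the lowest number, but it differs from compound 3 in several places at once, so nothing can be read from it about this one change. With no step of this kind shown among the measured compounds, the size of the step is expected to stay within the scatter. Compound 4 is expected to give 38%, between 26% and 50%, which means an expected step of a number 0.4 percentage points higher from compound 3 to compound 4 (within the scatter).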

Compound 4, a percentage reported as inhibition, in the whole organism at one dose (the size of the read-out at that dose, not a potency): 7.2%
Beside the measured number, compound 4's estimate is 30.8 percentage points above it, and the stated range ends above it.
By their numbers in this assay, from the lowest: compound 4; then compound 1; then compounds 2 and 3 (each within the scatter of the next).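

For the compounds shown here, this is the first single change that can be followed on its own in this assay: replacing benzyl with 3-chlorobenzyl on the sulfanyl group gives a number 30.4 percentage points lower from compound 3 to compound 4 (beyond the scatter), a large step beyond the scatter. The added chlorine is one heavy atom, with no ring, no net charge and no hydrogen-bond donor or acceptor counted for it, yet this single replacement on an aromatic carbon is enough to take the read-out far down at this dose. The benzyl end is therefore not indifferent to change at this place, although this rests on one pair and holds only with the rest of compound 3 kept as it is.

From the compounds shown here alone, it remains open whether the drop is specific to chloro or would also follow from a hydroxyl group, an amine or a carboxylic acid on the same aromatic carbon, and whether chloro would have the same effect with other groups elsewhere on the shared core. No measurement available here bears on why the number falls so far.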